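Swapping the sulfur-bound heteroaryl group on a shared core

The source may report more compounds than this note shows. Statements on the series, on what has been measured and on what is new or still open speak of the compounds shown alone.

Measured compounds:
Compound 1 `Cn1c(-c2ccc(NC(=O)CSc3nc4cc(Cl)ccc4o3)cc2)nc(-c2ccccc2)c1-c1ccccc1`: in a functional assay on MCF7 cells (Homo sapiens) for cytotoxicity, read by MTT assay, with a stated time of 24 h, tested at 0.64 ug/mL (a higher number here means a stronger effect of the compound at the concentration tested, a lower number a weaker effect), compound 1 gives 2.4%
Compound 2 `Cn1c(-c2ccc(NC(=O)CSc3nc4ccccc4s3)cc2)nc(-c2ccccc2)c1-c1ccccc1`: in this assay compound 2 gives 0.9%

Both compounds share one core and differ only in the group attached to a sulfur. Compound 1 stands highest of the two numbers, but its nearest neighbour compound 2 sits close: the step of a number 1.5 percentage points lower from compound 1 to compound 2 (within the scatter) is within the scatter, so the two read as equal.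

Compound 3 `Cc1nnc(SCC(=O)Nc2ccc(-c3nc(-c4ccccc4)c(-c4ccccc4)n3C)cc2)s1` has not yet been measured. Its change from compound 1 is 5-methyl-1,3,4-thiadiazol-2-yl in place of 5-chloro-1,3-benzoxazol-2-yl on a sulfur. Among the measured compounds shown here, the only measured step that bears on this, the one from compound 1 to compound 2, also replaced the group on that sulfur and moved nothing beyond the scatter. Both measured values are near the bottom of the scale, so no step beyond the scatter in this assay is expected in either direction. Compound 3 is therefore estimated at 2%, in a range from 0% to 12%, a step of a number 0.4 percentage points lower from compound 1 to compound 3 (within the scatter).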

Compound 3, a percentage reported as activity, at one concentration (the size of the read-out at that concentration, not a potency): 35.1%
For compound 3 the middle estimate is 33.1 percentage points below the measured one, outside the stated range (above it).
By their numbers in this assay, from the lowest: compounds 2 and 1 (each within the scatter of the next); then compound 3.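

The group on the sulfur can clearly matter in this assay: a number 32.7 percentage points higher from compound 1 to compound 3 (beyond the scatter), and a number 34.2 percentage points higher from compound 2 to compound 3 (beyond the scatter), whereas the exchange of 5-chloro-1,3-benzoxazol-2-yl for 1,3-benzothiazol-2-yl moved nothing beyond the scatter. Among the compounds shown here, compound 3 carries 5-methyl-1,3,4-thiadiazol-2-yl, with one five-membered aromatic ring, where compound 1 carries a five-membered and a six-membered aromatic ring, and only this change lifts the number clear of the bottom of the scale. No measurement at hand gives a reason for this rise.

A single compound cannot tell whether the rise belongs to the thiadiazole ring or to its methyl. A 1,3,4-thiadiazol-2-yl carrying a hydrogen, an amine or an ethyl in place of that methyl would separate the two.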